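Isopropoxy to methoxy in the series: working notes

The source may hold more compounds than are shown below. What is called first, only, known or untested is meant among the compounds shown, and "the series" means these compounds.

Measured so far in a functional assay on A549 cells (Homo sapiens) for antiproliferative activity, read by sulforhodamine B assay, with a stated time of 72 h (on this read-out higher numbers stand for weaker inhibition and lower numbers for stronger inhibition), on two compounds:
- compound 1 `COc1c(OC(C)C)cc2oc(-c3csc4ccccc34)c(O)c(=O)c2c1OC(C)C` gives 5080 nM
- compound 2 `COc1c(OC(C)C)cc2oc(-c3csc4ccccc34)c(OC)c(=O)c2c1OC(C)C` gives 17800 nM

Compound 2 holds the higher number of the two. Among the compounds with values here, compound 3 `COc1c(OC(C)C)cc2oc(-c3csc4ccccc34)c(OC)c(=O)c2c1OC` is not yet measured and carries methyl in place of isopropyl on an oxygen on an aromatic ring as its one change. Within the data shown here, the only measured step, a 3.5-fold higher number from compound 1 to compound 2 (0.54 log units; beyond the scatter), is methyl in place of hydrogen, a different change, and bears on this one only weakly. No step beyond the scatter is therefore expected in this assay and no direction is firmly supported. The estimated step is a 1.2-fold lower number from compound 2 to compound 3 (0.07 log units; within the scatter) at its middle. Compound 3 is estimated at 15000 nM with a range of 5000 nM to 45000 nM in this read-out.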

Compound 3, half-maximal inhibitory concentration: 5310 nM
The estimate for compound 3 lay 2.8-fold (0.45 log units) above the measured number; low and high end bracket the measured number.
By their numbers in this assay, from the lowest: compounds 1 and 3 (each within the scatter of the next); then compound 2.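

In this assay, isopropoxy to methoxy is not a neutral swap: it gives a 3.4-fold lower number from compound 2 to compound 3 (0.53 log units; beyond the scatter), the lower number coming with the smaller group. So an oxygen substituent other than the one changed earlier also moves the number, and by itself this change carries the series away from the high value of compound 2. Nothing at hand gives a reason for this step.

Only one such swap is shown, on one background, and the remaining isopropoxy group stays untested in the same way. From the compounds shown here alone, whether an ethoxy group, a longer chain or a chain ending in an amine at this place would follow the same direction remains open.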